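Phenyl for methyl on the side-chain carbinol carbon

This account rests on a few compounds, and the source may have more. Where it says the series, first, only, none or still open, it means among the compounds named here.

Of the compounds shown here, three sharing one core have been tested in an assay on brain for displacement of a labelled ligand from Adrenergic receptor alpha-1 (Rattus norvegicus); a lower number here means a stronger inhibitor, a higher number a weaker inhibitor. Compound 1 `CCOCCOC1CCN(c2nc(N)c3cc(OC)c(OC)cc3n2)CC1` gives 1.81 nM. Compound 2 `COc1cc2nc(N3CCC(OCCO)CC3)nc(N)c2cc1OC` gives 2.2 nM, and compound 3 `COc1cc2nc(N3CCC(OCC(C)(C)O)CC3)nc(N)c2cc1OC` gives 1.28 nM. Compound 3 has the lowest of the three numbers, but its steps to the others are small: a 1.4-fold lower number from compound 1 to compound 3 (0.15 log units; within the scatter) and a 1.7-fold lower number from compound 2 to compound 3 (0.24 log units; within the scatter), so the three stand together. Compound 4 `COc1cc2nc(N3CCC(OCC(C)(O)c4ccccc4)CC3)nc(N)c2cc1OC` is the next step: phenyl in place of methyl on a saturated chain carbon bound to an oxygen on a saturated carbon and two saturated chain carbons.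

Among the measured compounds shown here, all three steps so far concern this same end of the side chain, and none moved the number beyond the scatter: a 1.2-fold higher number from compound 1 to compound 2 (0.08 log units; within the scatter), a 1.4-fold lower number from compound 1 to compound 3 (0.15 log units; within the scatter), a 1.7-fold lower number from compound 2 to compound 3 (0.24 log units; within the scatter). None of them adds a ring, though, so the present change goes further than anything yet measured and the expectation carries more uncertainty. For the measured compounds named here, with no step of this kind to lean on, compound 4 is expected to stay near compound 3, with the step of a 1.3-fold higher number from compound 3 to compound 4 (0.10 log units; within the scatter) estimated to fall within the scatter. The estimate for compound 4 in this assay is 1.6 nM, with a range from 0.5 nM to 5 nM.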

Compound 4, inhibition constant: 0.62 nM
Compound 4: the middle estimate sits 2.6-fold (0.41 log units) above what was measured, and the stated range covers the measured number.
By their numbers in this assay, from the lowest: compound 4; then compounds 3, 1 and 2 (each within the scatter of the next).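

Among the compounds shown here, the step of a 2.1-fold lower number from compound 3 to compound 4 (0.31 log units; beyond the scatter) in this assay is the first at this end of the side chain to pass the scatter, and it is also the first to bring in a ring, here one six-membered aromatic ring of carbon only. The larger 1-hydroxy-1-phenylethyl group also stands clear of the two smaller side-chain ends, with a 3.5-fold lower number from compound 2 to compound 4 (0.55 log units; beyond the scatter) when it replaces hydroxymethyl and a 2.9-fold lower number from compound 1 to compound 4 (0.47 log units; beyond the scatter) when it replaces ethoxymethyl, so this saturated chain carbon accepts a phenyl group and the number falls, though each step is only modest. Nothing measured here speaks to what lies behind this drop.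

The compounds shown leave open whether the aromatic ring matters or only the added carbon, which a saturated cyclohexyl ring or a longer alkyl chain in the same place would help to separate. They also leave open how a fluorine or a methoxy group on the phenyl ring would shift the number, and what would follow if an amine took the place of the hydroxyl on this carbon.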